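This account rests on a few compounds, and the source may have more. Where it says the series, first, only, none or still open, it means among the compounds named here.

Measured so far:
- compound 1 `CN(C)c1nc(N)nc2c1ncn2/C=C1/CC1(CO)CO`: in an ADME assay on HFF cells (Homo sapiens) for cytotoxicity, with a stated time of 8 days (a higher number here means that more compound is tolerated, a lower number that less compound is tolerated), compound 1 gives > 300000 nM, a limit of the assay.
- compound 2 `CCCCCCSc1nc(N)nc2c1ncn2/C=C1/CC1(CO)CO`: in this assay compound 2 gives > 300000 nM, again a limit.

The step that the two limits leave unreadable from compound 1 to compound 2 cannot be read because both values sit at the limit of > 300000 nM in this assay, at which 2 of the 2 values shown sit. Compound 2 thus stands only at the limit, with no number of its own. Compound 3 `Nc1nc(SCc2ccccc2)c2ncn(/C=C3/CC3(CO)CO)c2n1` differs from compound 2 by phenyl in place of pentyl on a saturated chain carbon bound to a sulfur. Among the measured compounds shown here, the only measured step, a step that the two limits leave unreadable from compound 1 to compound 2, gives no readable size to carry over, so no shift beyond the scatter is expected. The step of a number no higher from compound 2 to compound 3 (the limit leaves the size open) is the estimate for compound 3. Compound 3 is therefore expected at 300000 nM, within 100000 nM to 1000000 nM, most likely again reported only as a limit.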

Compound 3, half-maximal cytotoxic concentration: > 300000 nM
Compound 3: no number, only a limit; the forecaster's own chance of this, stated with the estimate: 80%; the middle value sits exactly at the limit.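

Among the compounds shown here, no step among compound 1, compound 2 and compound 3 can be read in this assay: the limit of > 300000 nM in this assay, at which 3 of the 3 values shown sit. The compounds shown leave open at what concentration the dimethylamino, hexylsulfanyl or benzylsulfanyl compounds become cytotoxic, and whether these groups differ at all.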